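The source may hold more compounds than are shown below. What is called first, only, known or untested is meant among the compounds shown, and "the series" means these compounds.

Measured so far in the series:
compound 1 `C=C1[C@@H](OC(C)=O)C[C@@H]2[C@](C)(COC=O)[C@H](OC(C)=O)CC[C@@]2(C)[C@@H]1C[C@@H](Nc1ccccc1C(=O)O)C1=CCOC1=O` — 42500 nM
compound 2 `C=C1[C@@H](OC(C)=O)C[C@@H]2[C@](C)(CO[Si](C)(C)C(C)(C)C)[C@H](OC(C)=O)CC[C@@]2(C)[C@@H]1C[C@@H](Nc1cccc(F)c1)C1=CCOC1=O` — 4560 nM

Going by the values given here, in a functional assay on KB cells (Homo sapiens) for cytotoxicity, read by sulforhodamine B assay (a lower number here means a stronger inhibitor, a higher number a weaker inhibitor), compound 1 gives 42500 nM, the highest of the two numbers; compound 2 gives 4560 nM, a gap beyond the scatter, though the two structures differ in more than one place and no single step joins them. Compound 3 `C=C1[C@@H](OC(C)=O)C[C@@H]2[C@](C)(COC=O)[C@H](OC(C)=O)CC[C@@]2(C)[C@@H]1C[C@@H](Nc1ccc(F)cc1)C1=CCOC1=O` keeps the core of compound 1 with one change: 4-fluorophenyl in place of 2-carboxyphenyl on an amine nitrogen. For compound 3 a step of a 5.3-fold lower number from compound 1 to compound 3 (0.73 log units; beyond the scatter) is expected, a move to a lower number beyond the scatter, because compound 2 gives 4560 nM. Compound 3 is estimated at 8000 nM, with a range from 2500 nM to 25000 nM.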

Compound 3, half-maximal inhibitory concentration: 22900 nM
Estimate against measurement, compound 3: 2.9-fold (0.46 log units) below; the measured number falls inside the stated range.
By their numbers in this assay, from the lowest: compound 2; then compounds 3 and 1 (each within the scatter of the next).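

In this assay, going by these compounds alone, the first single-place step reads a 1.9-fold lower number from compound 1 to compound 3 (0.27 log units; within the scatter) and stays within the scatter, so exchanging 2-carboxyphenyl for 4-fluorophenyl on this amine nitrogen does not separate the two compounds. At this position, the carboxylic acid is therefore not needed to keep the number in this range. Nothing measured on hand bears on the reason for this result.

Unsubstituted phenyl, a methoxy-bearing phenyl and a saturated alkyl chain on this nitrogen remain open. From the compounds shown here alone, compound 2 differs from compound 3 in more than one place, so the role of the fluorine's ring position also remains open.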